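This account rests on a few compounds, and the source may have more. Where it says the series, first, only, none or still open, it means among the compounds named here.

Measured compounds:
Compound 1, `Cc1ccc(/C=C/C(=O)c2ccc(NC(=O)Nc3ccc(Cl)cc3)cc2)cc1`: in a functional assay on the whole organism (Abdomen, strain Swiss) for inhibition, with Mus musculus as the target, with a stated time of 30 min, at a dose of 10 mg/kg by the intraperitoneal route (a higher number here means more inhibition at the dose given (going by the name of the read-out), a lower number less inhibition), compound 1 gives 42.8%.
Compound 2, `O=C(Nc1ccc(Cl)cc1)Nc1ccc(C(=O)/C=C/c2ccc(Cl)cc2)cc1`: in this assay compound 2 gives 51%.

Of the two readings, that of compound 2 carries the numerically larger figure, but the step of a number 8.2 percentage points higher from compound 1 to compound 2 (within the scatter) lies within the scatter and so separates the two compounds in no real sense. The next compound, compound 3, `COc1ccc(/C=C/C(=O)c2ccc(NC(=O)Nc3ccc(Cl)cc3)cc2)cc1`, is derived from compound 2 by a single change: methoxy in place of chloro on an aromatic carbon.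

Within the data shown here, only one measured step bears on this change, and only loosely. The step of a number 8.2 percentage points higher from compound 1 to compound 2 (within the scatter) exchanged methyl for chloro at the same place on the ring and produced nothing beyond the scatter. Among the measured compounds shown here, no measured compound carries methoxy at that place, so the comparison of chloro against methoxy rests on that single, inconclusive step. On this basis a step in this assay of no meaningful size is expected from compound 2 to compound 3, in either direction. Compound 3 is therefore estimated at 45%, in a range from 28% to 62%. This estimate for compound 3 amounts to an expected step of a number 6 percentage points lower from compound 2 to compound 3 (within the scatter).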

Compound 3, a percentage reported as inhibition, in the whole organism at one dose (the size of the read-out at that dose, not a potency): 84.4%
Beside the measured number, compound 3's estimate is 39.4 percentage points below it, and the stated range ends below it.
By their numbers in this assay, from the lowest: compounds 1 and 2 (each within the scatter of the next); then compound 3.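

In this assay, the earlier exchange of methyl for chloro gave only a step within the scatter (a number 8.2 percentage points higher from compound 1 to compound 2 (within the scatter)), which left it unclear whether the aromatic carbon para to a large group responded to its substituent at all. Methoxy settles that question for this set of compounds: the step to it from chloro (a number 33.4 percentage points higher from compound 2 to compound 3 (beyond the scatter)) and the step to it from methyl (a number 41.6 percentage points higher from compound 1 to compound 3 (beyond the scatter)) both lie beyond the scatter, so the group at this place can strongly change the inhibition seen at this single dose. The change from 4-chlorophenyl to 4-methoxyphenyl adds one heavy atom and one hydrogen-bond acceptor, but no available evidence connects either difference with the higher reading.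

The compounds shown leave open whether this gain is specific to methoxy or extends to a hydroxyl, an ethoxy or a dimethylamino group at the same place. They also leave open whether the gain persists when the other end of the shared core changes, and how the three compounds would compare at other doses.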